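A fluoro step repeated on a dibromo core

The source may hold more compounds than are shown below. What is called first, only, known or untested is meant among the compounds shown, and "the series" means these compounds.

Four compounds share a dinitro-trifluoromethylphenyl ether joined to an oxime that carries a benzyl-type group. Compound 1 `O=[N+]([O-])c1cc(C(F)(F)F)cc([N+](=O)[O-])c1Oc1ccccc1/C=N\OCc1ccccc1` is the plain benzyl member. In a functional assay on MCF7 cells (Homo sapiens) for antiproliferative activity, read by MTT assay, with a stated time of 48 h (on this read-out lower numbers stand for stronger inhibition and higher numbers for weaker inhibition), compound 1 gives 1330 nM. Compound 2 `O=[N+]([O-])c1cc(C(F)(F)F)cc([N+](=O)[O-])c1Oc1ccccc1/C=N\OCc1ccccc1F` carries one change: fluoro in place of hydrogen on an aromatic carbon. In this assay compound 2 gives 700 nM, so that a 1.9-fold lower number from compound 1 to compound 2 (0.28 log units; within the scatter). Compound 3 `O=[N+]([O-])c1cc(C(F)(F)F)cc([N+](=O)[O-])c1Oc1c(Br)cc(Br)cc1/C=N\OCc1ccccc1` has a different core, carrying two bromine atoms; how its core differs from the core of compound 1 is not broken down here. In this assay compound 3 gives 1830 nM, a number that sits within the scatter of compound 1 but beyond the scatter of compound 2.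

Compound 4 `O=[N+]([O-])c1cc(C(F)(F)F)cc([N+](=O)[O-])c1Oc1c(Br)cc(Br)cc1/C=N\OCc1ccccc1F` is not yet measured. It stands to compound 3 as compound 2 stands to compound 1: fluoro in place of hydrogen on an aromatic carbon. The place of the change is described in the same words for both pairs, so this is the same change, made on a core that carries two bromine atoms instead of the core of compound 1. Going by the values given here, the expectation for this assay is that a 1.8-fold lower number from compound 3 to compound 4 (0.26 log units; within the scatter), because a 1.9-fold lower number from compound 1 to compound 2 (0.28 log units; within the scatter) and nothing among the measured compounds suggests the dibromo core responds differently. Compound 4 is therefore estimated at 1000 nM, with a likely range from 500 nM to 2000 nM.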

Compound 4, half-maximal inhibitory concentration: 880 nM
Estimate against measurement, compound 4: 1.1-fold (0.06 log units) above; low and high end bracket the measured number.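

Swapping benzyl for 2-fluorobenzyl on the core with two bromine atoms gives, in this assay, a 2.1-fold lower number from compound 3 to compound 4 (0.32 log units; beyond the scatter), a modest step. Set beside the step on the core of compound 1, it shows that this change carried over between these two cores with much the same size and the same direction, and that the two bromine atoms left no visible mark on the result: the same change on two cores in this assay, a 1.9-fold lower number (0.28 log units; within the scatter) from compound 1 to compound 2 and a 2.1-fold lower number (0.32 log units; beyond the scatter) from compound 3 to compound 4, 1.1-fold (0.04 log units) apart, within the scatter of two such steps. This is still a narrow finding, resting on one change, two cores and one cell read-out, with one of the two steps inside the usual scatter and the other only just past it, so it neither promises the same result on a third core nor explains why the fluoro lowers the number at all.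

What the compounds shown leave open is whether another group in the place of this fluoro, such as a chlorine atom, a methoxy group or an amine, would give a step of similar size. On these data alone, it is also open whether the match between the two cores would survive on a core with chlorine atoms in place of the bromine atoms, or with a longer chain in place of the benzyl group.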